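The compounds below may be only part of what the source reports. "The series", "measured", "known", "first", "only" and "open" are said of these compounds alone.

Working notes on the series. Compound 1 `CCCCOC(=O)NS(=O)(=O)c1sc(CC(C)C)cc1-c1ccc(CN2C(=O)N(C)C(C)(C)C2=O)cc1` gives 3.6 nM in an assay on membranes from uterus for displacement of a labelled ligand from Angiotensin type II receptor (Sus scrofa), with a stated time of 1.5 h; on this read-out higher numbers stand for weaker inhibition and lower numbers for stronger inhibition. Compound 2 `CCCCOC(=O)NS(=O)(=O)c1sc(CC(C)C)cc1-c1ccc(C(=O)c2ccnn2C)cc1` gives 3.4 nM in this assay. Among the measured compounds shown here, the only change between them, a 1.1-fold lower number from compound 1 to compound 2 (0.02 log units; within the scatter), keeps the number within the scatter; compound 2 and compound 1 therefore stand at the same level, and neither can be set ahead of the other on what has been measured so far.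

Compound 3 `CCCCOC(=O)NS(=O)(=O)c1sc(CC(C)C)cc1-c1ccc(Cn2ccc(C(F)(F)F)n2)cc1` is not yet measured. It differs from compound 2 by (3-(trifluoromethyl)-1H-pyrazol-1-yl)methyl in place of (1-methyl-1H-pyrazol-5-yl)carbonyl on an aromatic carbon. For the measured compounds named here, the one measured step that bears on this part of the structure is the exchange of the group on the same aromatic carbon from compound 1 to compound 2, which was a 1.1-fold lower number from compound 1 to compound 2 (0.02 log units; within the scatter) and so gave no movement beyond the scatter. Going by the values given here, on that basis the step from compound 2 to compound 3 in this assay is expected to be small, a 1.5-fold higher number from compound 2 to compound 3 (0.17 log units; within the scatter), with no clear direction, and a somewhat wider range is allowed because only a single step informs it. Compound 3 is estimated at 5 nM, with a range from 1.5 nM to 20 nM.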

Compound 3, inhibition constant: 9.5 nM
Compound 3: middle estimate off by 1.9-fold (0.28 log units), on the low side; the range from low to high includes it.
By their numbers in this assay, from the lowest: compounds 2 and 1 (each within the scatter of the next); then compound 3.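

In this assay, this position gives its first movement beyond the scatter: a 2.8-fold higher number from compound 2 to compound 3 (0.45 log units; beyond the scatter), and a 2.6-fold higher number from compound 1 to compound 3 (0.42 log units; beyond the scatter), both modest. The earlier exchange at this aromatic carbon left the number unchanged within the scatter, so the position is now seen not to accept every group equally, although the two new steps show only a limited penalty. The step from compound 1 keeps the saturated chain carbon and exchanges only the group on it, which shows that this exchange alone moves the number, whereas the step from compound 2 also replaces the carbonyl with that chain carbon; no measurement shown here explains the shift.

Going by these compounds, it remains open which part of the 3-(trifluoromethyl)-1H-pyrazol-1-yl group carries the step, and a 3-methyl-1H-pyrazol-1-yl group on the same saturated chain carbon would separate the trifluoromethyl from the ring. Also open, on these data alone, is whether a carboxylic acid or an amine on that chain carbon would stay at the level of compound 1 and compound 2 or fall further away.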